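An Oxetane at the Chain End of Compound 3

A few compounds are considered here, and "the series" means these few. Any claim that something is new, unique, unknown or untested is made for them only; others in the source may bear on it.

Of the compounds shown here, three sharing one core have been measured. Compound 1 `C[C@@H](NC(=O)c1ccc(C#Cc2cccc(F)c2)nn1)C(C)(C)O` gives 16.5% in an ADME assay on HEK293 cells for agonist activity at metabotropic glutamate receptor 5 (Rattus norvegicus), read by fluorescence and calcium flux; on this read-out higher numbers stand for larger maximal responses and lower numbers for smaller maximal responses. Compound 2 `C[C@H](NC(=O)c1ccc(C#Cc2cccc(F)c2)cn1)C(C)(C)C` gives 20%, and compound 3 `CCCNC(=O)c1ccc(C#Cc2cccc(F)c2)cn1` gives 8.3%. Among the compounds with values here, the only step between two compounds that differ in one place is a number 11.7 percentage points lower from compound 2 to compound 3 (beyond the scatter). The number for compound 3 lies within the scatter of that of compound 1 and beyond that of compound 2.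

Compound 4 `CC1(CCNC(=O)c2ccc(C#Cc3cccc(F)c3)cn2)COC1` differs from compound 3 by 3-methyloxetan-3-yl in place of methyl on a saturated chain carbon, two bonds along the chain from an amide-type nitrogen. Within the data shown here, no measured step touches this position; the step from compound 2 to compound 3 changed the group on the same amide-type nitrogen and moved the response only modestly, so a change of similar or smaller size, most likely none beyond the scatter, is expected here. Compound 4 is therefore expected to give about 10%, somewhere between 3% and 22%. This estimate corresponds to an expected step of a number 1.7 percentage points higher from compound 3 to compound 4 (within the scatter).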

Compound 4, largest response reached (reported as efficacy), in percent of the reference or control that the assay uses: 16.3%
Compound 4: the middle estimate sits 6.3 percentage points below what was measured, within the range that was stated.
By their numbers in this assay, from the lowest: compounds 3, 4, 1 and 2 (each within the scatter of the next, the first and the last beyond it).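

In this assay, the change to 3-methyloxetan-3-yl on this saturated chain carbon amounts to a number 8 percentage points higher from compound 3 to compound 4 (within the scatter), so this position accepts a far larger group with a four-membered ring and no change beyond the scatter. Compared with the 1,2,2-trimethylpropyl group on the amide-type nitrogen, the 2-(3-methyloxetan-3-yl)ethyl group gives a number 3.7 percentage points lower from compound 2 to compound 4 (within the scatter) and thus no separation either. No evidence at hand explains these results. Going by these compounds, whether the ring oxygen matters remains open, and a 1-methylcyclobutyl group would test this. On these data alone, how an amine or a carboxylic acid at this chain end would read also remains open.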